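Aryl swap at the oxazole: dibromophenyl to dimethoxyphenyl

A few compounds are considered here, and "the series" means these few. Any claim that something is new, unique, unknown or untested is made for them only; others in the source may bear on it.

Working notes on the series. The reference here is compound 2 `Cc1oc(-c2c(Br)cccc2Br)nc1CN1CCC(C(=O)NCCCN2C[C@H](C)C[C@H](C)C2)CC1`, which in an ADME assay on Huh7.5.1 cells (Homo sapiens) for cytotoxicity, read by ATP content, with a stated time of 48 h (a higher number here means that more compound is tolerated, a lower number that less compound is tolerated), gives 6500 nM. Among the three measured compounds it stands second highest; its nearest neighbour is compound 1 `Cc1ccccc1-c1nc(CN2CCC(C(=O)NCCCN3CCCC(C(C)C)C3)CC2)c(C)o1`, which in this assay gives 5820 nM, a gap within the scatter, and its furthest is compound 3 `CCCN(CCC)CCNC(=O)C1CCN(Cc2nc(-c3ccccc3C)oc2C)CC1`, which in this assay gives 30500 nM, a gap beyond the scatter.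

Among the compounds with values here, the one measured step, a 5.2-fold higher number from compound 1 to compound 3 (0.72 log units; beyond the scatter), concerns the amine end of the chain. It does not touch the aryl group on the shared core and therefore says nothing direct about the change considered now, (3,4-dimethoxyphenyl in place of 2,6-dibromophenyl on an aromatic carbon), which leads to compound 4 `COc1ccc(-c2nc(CN3CCC(C(=O)NCCCN4C[C@H](C)C[C@H](C)C4)CC3)c(C)o2)cc1OC`. Within the data shown here, no measured pair varies this aryl group, so no step beyond the scatter is expected in this assay in either direction; the expected step is a 1.1-fold higher number from compound 2 to compound 4 (0.03 log units; within the scatter). On that basis compound 4 is estimated at 7000 nM, with a range from 3000 nM to 16000 nM.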

Compound 4, half-maximal cytotoxic concentration: 57200 nM
Estimate against measurement, compound 4: 8.2-fold (0.91 log units) below, and the stated range ends below it.
By their numbers in this assay, from the lowest: compounds 1 and 2 (each within the scatter of the next); then compounds 3 and 4 (each within the scatter of the next).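

The aryl position on the shared core is not silent in this assay: 3,4-dimethoxyphenyl in place of 2,6-dibromophenyl gives an 8.8-fold higher number from compound 2 to compound 4 (0.94 log units; beyond the scatter), with the amine end of the chain left unchanged. The earlier step, a 5.2-fold higher number from compound 1 to compound 3 (0.72 log units; beyond the scatter), concerned the amine end alone, so both ends of the series now carry a step beyond the scatter. Nothing measured on these compounds accounts for the aryl step, and it cannot be divided between the departure of the bromines and the arrival of the methoxy groups.

On these data alone, a plain phenyl group at this position would show how much of the step goes with each of those two parts, and that remains open. Also open, as far as these compounds go, is whether a similar step appears when the aryl group changes alongside the dipropylamino end of compound 3.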